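A few compounds are considered here, and "the series" means these few. Any claim that something is new, unique, unknown or untested is made for them only; others in the source may bear on it.

Measured compounds:
Compound 1, `COc1cccc(-c2c(S(=O)(=O)c3ccc(C)c(F)c3)cnc3c(F)cccc23)c1`, in an ADME assay on microsomes from liver (Homo sapiens) for metabolic stability, tested at 2.5 uM (on this read-out higher numbers stand for fast clearance and lower numbers for slow clearance), gives 4.02 mL/min.
Compound 2, `COc1ccc(-c2c(S(=O)(=O)c3cc(F)cc(F)c3)cnc3c(F)cccc23)cc1`, in this assay gives 2.59 mL/min.

Compound 2 and compound 1 differ in two places at once, so no single step can be read between them; what their two numbers show is that the gap between them lies within the usual scatter of this assay, and neither compound can be set apart from the other on clearance. Compound 2 thus stands among numbers that are, for practical purposes, one level.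

Compound 3, `COc1ccc(-c2c(S(=O)(=O)c3ccc(C)c(F)c3)cnc3c(F)cccc23)cc1`, has not yet been measured. It differs from compound 2 by 3-fluoro-4-methylphenyl in place of 3,5-difluorophenyl on a sulfonyl sulfur. Going by the values given here, the sulfonyl-bound ring it carries is the one found in compound 1, while the rest of the molecule is that of compound 2. Among the compounds with values here, the only guide is that compound 1 gives 4.02 mL/min and compound 2 gives 2.59 mL/min, both within the scatter of each other, so the exchange of the ring on the sulfonyl sulfur is expected to move clearance little, if at all, beyond the scatter in this assay. Compound 3 is therefore expected to fall near both measured compounds, with an estimated step of a 1.3-fold higher number from compound 2 to compound 3 (0.11 log units; within the scatter), and an expected value of 3.3 mL/min, in a range from 1.8 mL/min to 6 mL/min.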

Compound 3, intrinsic clearance in a liver preparation (reported as CLH), per the amount of preparation that the assay uses: 3.27 mL/min
Estimate against measurement, compound 3: 1.0-fold (0.00 log units) above, and the stated range covers the measured number.
By their numbers in this assay, from the lowest: compounds 2, 3 and 1 (each within the scatter of the next).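

In this assay, the exchange of 3,5-difluorophenyl for 3-fluoro-4-methylphenyl on a sulfonyl sulfur can now be read on its own, with the rest of the molecule held the same, and the step (a 1.3-fold higher number from compound 2 to compound 3 (0.10 log units; within the scatter)) shows that clearance does not separate these two rings. Compound 3 also connects compound 1 to the series through a second single change, 4-methoxyphenyl in place of 3-methoxyphenyl on an aromatic carbon, and that step (a 1.2-fold lower number from compound 1 to compound 3 (0.09 log units; within the scatter)) stays inside the scatter as well, which compound 1 and compound 2 could not show while they differed in two places at once. Nothing measured here accounts for either result.

On these data alone, both single changes leave the three compounds on one level, so it remains open whether any group on the sulfonyl-bound ring could move clearance beyond the scatter, for example an amine or a carboxylic acid in place of the methyl of 3-fluoro-4-methylphenyl. As far as these compounds go, it also remains open what a hydroxyl group or a longer alkoxy chain in place of the methoxy group would do to clearance in these compounds.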